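This account rests on a few compounds, and the source may have more. Where it says the series, first, only, none or still open, it means among the compounds named here.

The two measured compounds are compound 1 `O=C(NCCCCc1ccccc1)c1cccc(C2SCC(=O)N2c2cccc(-c3c[nH]nn3)c2)c1` and compound 2 `CCOc1ccccc1N1C(=O)C(C)SC1c1cccc(C(=O)NCCCCc2ccccc2)c1`. In a functional assay on HOS-TE85 cells (Homo sapiens) for inhibition, read by CCK-8 assay, with a stated time of 72 h (a higher number here means a weaker inhibitor, a lower number a stronger inhibitor), compound 1 gives 110 nM, and compound 2 gives 71.6 nM. Compound 1 thus has the higher of the two numbers, but the gap to compound 2 is within the scatter of repeated measurements, so the two values show no real difference in potency.

Compound 3 `O=C(NCCCCc1ccccc1)c1cccc(C2SCC(=O)N2c2nccs2)c1` has not yet been measured. Compared with compound 1, the change is a group of 5 heavy atoms (3 carbon, 1 nitrogen, 1 sulfur; one five-membered aromatic ring with 2 hetero atoms) in place of a group of 11 heavy atoms (8 carbon, 3 nitrogen; one five-membered aromatic ring with 3 hetero atoms, one six-membered aromatic ring of carbon only), on an amide-type nitrogen in a ring. Among the compounds with values here, no step between measured compounds that isolates a change of this kind is available, so the expectation rests on the values of compound 1 and compound 2 alone and on the size of the group removed. Compound 3 is expected to show a moderate move toward a higher number, a 2.0-fold higher number from compound 1 to compound 3 (0.30 log units; within the scatter), as the replacement removes most of what sits on the amide-type nitrogen in the ring. For compound 3 the estimated value in this assay is 220 nM, with a range from 60 nM to 800 nM.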

Compound 3, half-maximal inhibitory concentration: > 1000 nM
Compound 3 was reported as a limit; the forecaster's own chance of this, stated with the estimate: 10%; at least 4.5-fold (0.65 log units) between middle value and limit.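

Within the data shown here, at the amide-type nitrogen in the ring, the earlier compounds gave no step, and this change now gives one: replacing the larger group with 1,3-thiazol-2-yl produces an at least 9.0-fold higher number from compound 1 to compound 3 (0.95 log units; beyond the scatter) in this assay. For compound 3, > 1000 nM is a limit of the assay and not a number. The position therefore does not accept this exchange without a clear loss of potency, though only the lower bound of that loss is known: the limit of > 1000 nM in this assay, at which 1 of the 3 values shown sits.

The change removes the six-membered carbon ring and the five-membered ring with 3 hetero atoms together, and the compounds shown do not tell which of them matters. As far as these compounds go, whether a plain phenyl on that nitrogen, or a phenyl carrying a carboxylic acid or an amine in place of the five-membered ring, would keep the potency of compound 1 also remains open.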